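This account rests on a few compounds, and the source may have more. Where it says the series, first, only, none or still open, it means among the compounds named here.

Working notes on the series. Among the compounds with values here, compound 3 `O=C(/C=C/c1ccccc1Cl)Nc1ccc2ncnc(Nc3cccc(Cl)c3)c2c1` gives 1.74 ug/mL in a functional assay on B16-F10 cells (Mus musculus) for inhibition, read by MTT assay, with a stated time of 48 h; a higher number here means a weaker inhibitor, a lower number a stronger inhibitor; among the three numbers so far it stands second highest, with compound 1 `O=C(/C=C/c1ccccc1Cl)Nc1ccc2ncnc(Nc3cccc(Br)c3)c2c1` nearest at 2 ug/mL and compound 2 `COc1ccc(/C=C/C(=O)Nc2ccc3ncnc(Nc4cccc(Br)c4)c3c2)cc1` furthest at 1.24 ug/mL, both gaps within the scatter. The step to compound 4 `COc1cccc(/C=C/C(=O)Nc2ccc3ncnc(Nc4cccc(Cl)c4)c3c2)c1` is 3-methoxyphenyl in place of 2-chlorophenyl on a double-bonded chain carbon bound to a double-bonded chain carbon. Within the data shown here, two measured steps bear on it: the closest parallel is the step from compound 1 to compound 2, where a methoxyphenyl replaced the same 2-chlorophenyl, giving a 1.6-fold lower number from compound 1 to compound 2 (0.21 log units; within the scatter); the step from compound 1 to compound 3, a 1.1-fold lower number from compound 1 to compound 3 (0.06 log units; within the scatter), shows that the halogen on the other aromatic ring does little here. Among the measured compounds shown here, no measured pair separates a 3-methoxyphenyl from a 4-methoxyphenyl, so that part of the change is unanchored. The expectation for compound 4 is therefore a small step, if any, toward a lower number, a 1.3-fold lower number from compound 3 to compound 4 (0.13 log units; within the scatter), within the scatter. Compound 4 is estimated at 1.3 ug/mL in this assay, with a range from 0.6 ug/mL to 3 ug/mL.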

Compound 4, half-maximal inhibitory concentration: 1.05 ug/mL
Beside the measured number, compound 4's estimate is 1.2-fold (0.09 log units) above it, and the stated range covers the measured number.
By their numbers in this assay, from the lowest: compounds 4, 2, 3 and 1 (each within the scatter of the next).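

In this assay, within the data shown here, a 1.7-fold lower number from compound 3 to compound 4 (0.22 log units; within the scatter) is the first step at this position on the chloro side of the series, and it replaces 2-chlorophenyl with 3-methoxyphenyl, adding one hydrogen-bond acceptor. Together with the bromo-side step, a 1.6-fold lower number from compound 1 to compound 2 (0.21 log units; within the scatter), it shows that two different methoxyphenyl groups at this place, each on a different halogen background, both leave the number within the scatter. No measurement shown accounts for these small steps.

The compounds shown leave open whether the 3-methoxyphenyl and 4-methoxyphenyl groups differ on an otherwise identical molecule. They also leave open how far this position stays so flat once the aromatic ring carries an amine or a carboxylic acid, or gives way to a saturated alkyl chain.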